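The source may hold more compounds than are shown below. What is called first, only, known or untested is meant among the compounds shown, and "the series" means these compounds.

Compound 1 `CC(C)COc1nc(C(C)(C)C)ccc1CNC(=O)C(C)c1ccc(NS(C)(=O)=O)c(F)c1`: 0.6 nM
Compound 2 `CC(C(=O)NCc1ccc(C(C)(C)C)nc1OC1CCCC1)c1ccc(NS(C)(=O)=O)c(F)c1`: 1.5 nM
Compound 3 `CC(C(=O)NCc1ccc(C(C)(C)C)nc1OCc1ccccc1)c1ccc(NS(C)(=O)=O)c(F)c1`: 4.4 nM

These numbers come from an assay on cells for antagonist activity at transient receptor potential cation channel subfamily V member 1 (Homo sapiens), read by FLIPR and calcium flux, with a stated time of 6 min; a lower number here means a stronger inhibitor, a higher number a weaker inhibitor. Compound 3 has the highest number of the three, with a 2.9-fold higher number from compound 2 to compound 3 (0.47 log units; beyond the scatter) and a 7.3-fold higher number from compound 1 to compound 3 (0.87 log units; beyond the scatter).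

Compound 4 `COc1ccc(CSc2nc(C(C)(C)C)ccc2CNC(=O)C(C)c2ccc(NS(C)(=O)=O)c(F)c2)cc1` differs from compound 3 in one place: (4-methoxybenzyl)sulfanyl in place of benzyloxy on an aromatic carbon. All three measured steps alter the group on that same oxygen, and each gave a weaker inhibitor: a 2.5-fold higher number from compound 1 to compound 2 (0.40 log units; beyond the scatter), a 7.3-fold higher number from compound 1 to compound 3 (0.87 log units; beyond the scatter) and a 2.9-fold higher number from compound 2 to compound 3 (0.47 log units; beyond the scatter). Going by the values given here, none of them replaces the oxygen itself, so no step matches the present change exactly, but every change made there so far has raised the number. A modest further rise is therefore expected, a 2.0-fold higher number from compound 3 to compound 4 (0.31 log units; beyond the scatter). Compound 4 is estimated at 9 nM, with a range from 3 nM to 30 nM.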

Compound 4, inhibition constant: 3.5 nM
Compound 4: the middle estimate sits 2.6-fold (0.41 log units) above what was measured; measured number inside the range.
By their numbers in this assay, from the lowest: compound 1; then compound 2; then compounds 4 and 3 (each within the scatter of the next).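

Going by these compounds alone, putting (4-methoxybenzyl)sulfanyl in place of benzyloxy swaps the oxygen on the aromatic carbon for sulfur and adds a methoxy group, yet the result is a 1.3-fold lower number from compound 3 to compound 4 (0.10 log units; within the scatter) and this is the first change at this position that stays within the scatter. The sulfur-linked compound still gives weaker inhibition than the two other oxygen-linked compounds, with a 2.3-fold higher number from compound 2 to compound 4 (0.37 log units; beyond the scatter) and a 5.8-fold higher number from compound 1 to compound 4 (0.77 log units; beyond the scatter) in the comparisons with cyclopentyloxy and isobutoxy. No measurement available here explains these results.

From the compounds shown here alone, since the sulfur and the methoxy group arrive together, their separate contributions remain unknown, and the plain benzylsulfanyl group would separate them. Going by these compounds, how an amine attached directly at this carbon would compare also remains open.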